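Trimming One Carbon from Compound 2

The source may report more compounds than this note shows. Statements on the series, on what has been measured and on what is new or still open speak of the compounds shown alone.

Compound 1 `COc1cccc(N2CCN(C(=O)C(C)N3C(=O)CCC3=O)CC2)c1` gives 0% in a functional assay on the whole organism (strain Swiss) with Mus musculus as the target, in the maximal electroshock model, with a stated time of 2 h, at a dose of 300 mg/kg by the intraperitoneal route; on this read-out lower numbers stand for a weaker effect and higher numbers for a stronger effect at the one dose given.
Compound 2 `CCC(C(=O)N1CCN(c2cccc(C(F)(F)F)c2)CC1)N1C(=O)CCC1=O` gives 50% in this assay.

Compound 2 stands highest of these two numbers; its nearest neighbour is compound 1, which lies lower by a gap beyond the usual scatter of this assay. Compound 3 `CC(C(=O)N1CCN(c2cccc(C(F)(F)F)c2)CC1)N1C(=O)CCC1=O` has not yet been measured. It differs from compound 2 by hydrogen in place of methyl on a saturated chain carbon, two bonds along the chain from an amide-type nitrogen in a ring and a carbonyl carbon. Going by the values given here, no measured pair shows this single change, so the size of its step is open. A modest downward step in this assay is expected, small enough that it may fall within the scatter. Compound 3 is estimated to give 25%, with a range from 0% to 60%. The expected step is a number 25 percentage points lower from compound 2 to compound 3 (beyond the scatter).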

Compound 3, a percentage reported as activity, at one dose (the size of the read-out at that dose, not a potency): 100%
Estimate against measurement, compound 3: 75 percentage points below, and the stated range ends below it.
By their numbers in this assay, from the lowest: compound 1; then compound 2; then compound 3.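

In this assay the chain carbon proves sensitive: shortening ethyl to methyl gives a number 50 percentage points higher from compound 2 to compound 3 (beyond the scatter), so the shorter chain is the better of these two. With that methyl kept, trifluoromethyl in place of methoxy on the aromatic carbon gives a number 100 percentage points higher from compound 1 to compound 3 (beyond the scatter), separating an effect that compound 1 and compound 2 could not show, as they differ in two places. Nothing measured here explains either step. The compounds shown leave open how a propyl chain would read at the chain carbon, and how a chlorine would read on the aromatic carbon.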